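The compounds below may be only part of what the source reports. "The series", "measured", "known", "first", "only" and "open" are said of these compounds alone.

In a functional assay on A-375 cells (Homo sapiens) for inhibition, read by CCK-8 assay, with a stated time of 72 h, tested at 2 uM (on this read-out lower numbers stand for less inhibition of growth and higher numbers for more inhibition of growth at the one concentration tested), compound 3 `COc1ccc(SCc2ccc(C(=O)Nc3ccccc3N)cc2)cc1` gives 10.2% and so lies within the scatter of the other two measured compounds. Compound 1 `Cc1cc(C)cc(SCc2ccc(/C=C/C(=O)Nc3ccccc3N)cc2)c1` gives 8.78% in this read-out and compound 2 `Nc1ccccc1NC(=O)/C=C/c1ccc(CSc2cccc(F)c2)cc1` gives 6.75% there, so none of the three stands apart.

The change to compound 4 `CCc1ccc(SCc2ccc(C(=O)Nc3ccccc3N)cc2)cc1` is a single substitution: ethyl in place of methoxy on an aromatic carbon with ethyl in place of methoxy on an aromatic carbon, para to a large group. Within the data shown here, the only measured step that bears on this is a number 2 percentage points lower from compound 1 to compound 2 (within the scatter) and it too concerns the group on a sulfur, though in compounds with a core other than that of compound 3. It is one step on a different core, so it is weak guidance. Among the measured compounds shown here, with only that step to go on, no step beyond the scatter is expected in this assay and no direction can be given. The estimated step is a number 0.2 percentage points lower from compound 3 to compound 4 (within the scatter) and is expected to stay within the scatter. For compound 4 the expected value is 10% with an estimated range from 3% to 20% in this read-out.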

Compound 4, percent growth inhibition at one concentration: 19.6%
Compound 4: the middle estimate sits 9.6 percentage points below what was measured; measured number inside the range.
By their numbers in this assay, from the lowest: compounds 2, 1, 3 and 4 (each within the scatter of the next, the first and the last beyond it).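

In this assay, among these compounds, the swap of methoxy for ethyl on an aromatic carbon, para to a large group, gives the first reading at this position on the shared core of compound 3: a number 9.4 percentage points higher from compound 3 to compound 4 (within the scatter). The change from 4-methoxyphenyl to 4-ethylphenyl, which takes out the oxygen and its one hydrogen-bond acceptor, therefore does not separate the two compounds at the one concentration tested. Nothing available explains the size of this step.

Going by these compounds, it remains open whether any group at this position can move growth inhibition beyond the scatter, and an amine, a carboxylic acid or a longer chain there would test this. Also open, on these data alone, is whether the same swap reads alike on the core of compound 1.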